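A few compounds are considered here, and "the series" means these few. Any claim that something is new, unique, unknown or untested is made for them only; others in the source may bear on it.

Measured so far in a functional assay on SW-620 cells (Homo sapiens) for cytotoxicity, read by MTT assay, with a stated time of 72 h; a lower number here means a stronger inhibitor, a higher number a weaker inhibitor:
- Compound 1 `COc1cccc(/C=C2\CCC/C(=C\c3ccccc3Br)C2=O)c1OC` gives 12100 nM
- Compound 2 `COc1cccc(/C=C2\CCC/C(=C\c3ccc(O)cc3)C2=O)c1OC` gives > 20000 nM, which is a limit of the assay
- Compound 3 `COc1cccc(/C=C2\CCC/C(=C\c3cccc(Cl)c3Cl)C2=O)c1OC` gives 16300 nM

The two true numbers stand close together, with a 1.3-fold higher number from compound 1 to compound 3 (0.13 log units; within the scatter). Compound 4 `COc1cccc(/C=C2\CCC/C(=C\c3ccc(O)c(Cl)c3)C2=O)c1OC` is not yet measured. In it, 3-chloro-4-hydroxyphenyl takes the place of 2,3-dichlorophenyl, on a double-bonded chain carbon bound to a double-bonded ring carbon: 3-chloro-4-hydroxyphenyl in place of 2,3-dichlorophenyl on a double-bonded chain carbon bound to a double-bonded ring carbon. The nearest evidence comes from the 4-hydroxyphenyl group of compound 2, where the steps are an at least 1.6-fold higher number from compound 1 to compound 2 (0.21 log units; that floor lies within the scatter) and an at least 1.2-fold lower number from compound 2 to compound 3 (0.08 log units; that floor lies within the scatter). None of these shows a change beyond the scatter, so no step beyond it is expected in this assay. The expected step is a 1.2-fold lower number from compound 3 to compound 4 (0.07 log units; within the scatter). For compound 4 the estimated value is 14000 nM, with an expected range from 6000 nM to 25000 nM.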

Compound 4, half-maximal inhibitory concentration: 16800 nM
Compound 4: the middle estimate sits 1.2-fold (0.08 log units) below what was measured; the range from low to high includes it.
By their numbers in this assay, from the lowest: compounds 1, 3 and 4 (each within the scatter of the next). At a limit, above all of these: compound 2.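

In this assay, 3-chloro-4-hydroxyphenyl in place of 2,3-dichlorophenyl gives a 1.0-fold higher number from compound 3 to compound 4 (0.01 log units; within the scatter), and in place of 2-bromophenyl it gives a 1.4-fold higher number from compound 1 to compound 4 (0.14 log units; within the scatter), so a ring bearing hydroxy at this position now has a true number, within the scatter of the halogen-only rings. Chloro in place of hydrogen on an aromatic carbon gives an at least 1.1-fold lower number from compound 2 to compound 4 (0.07 log units; that floor lies within the scatter), which is only a floor. Compound 2 remains a limit, not a number: the limit of > 20000 nM in this assay, at which 1 of the 4 values shown sits.

The rings shown carry only halogens and hydroxy, so it stays open whether an amine or a carboxylic acid on the ring would move the number beyond the scatter.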